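The source may report more compounds than this note shows. Statements on the series, on what has been measured and on what is new or still open speak of the compounds shown alone.

- Compound 1 `COc1ccccc1-c1ccc(CNc2nc(NC3CCC(N)CC3)nc3c2ncn3C2CCCC2)cc1`: 347 nM
- Compound 2 `NC1CCC(Nc2nc(NCc3ccc(-c4ccco4)cc3)c3ncn(C4CCCC4)c3n2)CC1`: 96 nM
- Compound 3 `NC1CCC(Nc2nc(NCc3ccc(-c4ccsc4)cc3)c3ncn(C4CCCC4)c3n2)CC1`: 150 nM

In a functional assay on K562 cells (Homo sapiens) for inhibition, with a stated time of 72 h (on this read-out lower numbers stand for stronger inhibition and higher numbers for weaker inhibition), compound 1 has the highest number of the three measured compounds, at 347 nM, and its steps to both of the others lie beyond the scatter. The next compound to consider is compound 4 `NC1CCC(Nc2nc(NCc3ccc(-n4cccn4)cc3)c3ncn(C4CCCC4)c3n2)CC1`, which has not yet been measured. It differs from compound 1 at a single place: 1H-pyrazol-1-yl in place of 2-methoxyphenyl on an aromatic carbon. In words, 1H-pyrazol-1-yl takes the place of 2-methoxyphenyl on an aromatic carbon, para to a large group.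

Two measured steps replace the same 2-methoxyphenyl group. With furan-2-yl the result is a 3.6-fold lower number from compound 1 to compound 2 (0.56 log units; beyond the scatter), and with thiophen-3-yl it is a 2.3-fold lower number from compound 1 to compound 3 (0.36 log units; beyond the scatter). Both steps are modest and point the same way. The step of a 1.6-fold higher number from compound 2 to compound 3 (0.19 log units; within the scatter) lies within the scatter, so the two replacements are not told apart in this assay. Within the data shown here, no measured compound carries 1H-pyrazol-1-yl, so these steps are only an indirect guide and the range must stay wide. A similar modest step in the same direction is therefore expected, estimated as a 2.7-fold lower number from compound 1 to compound 4 (0.43 log units; beyond the scatter). For compound 4 the expected value is 130 nM, with an estimated range of 50 nM to 300 nM.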

Compound 4, half-maximal inhibitory concentration: 119 nM
Compound 4: middle estimate off by 1.1-fold (0.04 log units), on the high side, and the stated range covers the measured number.
By their numbers in this assay, from the lowest: compounds 2, 4 and 3 (each within the scatter of the next); then compound 1.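

In this assay, 1H-pyrazol-1-yl on an aromatic carbon, para to a large group, gives a 2.9-fold lower number from compound 1 to compound 4 (0.46 log units; beyond the scatter) and so extends to a ring with 2 hetero atoms the direction already seen with furan-2-yl and thiophen-3-yl; all three five-membered aromatic rings now stand below compound 1, and no compound shown goes against this. The further steps, a 1.3-fold lower number from compound 3 to compound 4 (0.10 log units; within the scatter) and a 1.2-fold higher number from compound 2 to compound 4 (0.09 log units; within the scatter), lie within the scatter, so the three rings are not told apart in this assay and the change of ring from one to another has no readable effect at this place. Nothing measured here bears on why the number moves when 2-methoxyphenyl leaves.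

On these data alone, it stays open whether the higher number of compound 1 goes with its methoxy group or with its six-membered aromatic ring of carbon only, a question that a plain phenyl group at this place would separate. How a non-aromatic group, such as morpholine, a primary amine or a carboxylic acid, would read at this place is open as well.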